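The compounds below may be only part of what the source reports. "The series", "measured", "known", "first", "only" and "open" are said of these compounds alone.

Measured compounds in an ADME assay on HepG2 cells (Homo sapiens) for cytotoxicity, read by luminescence, CellTiter-Glo and ATP content, with a stated time of 72 h; on this read-out higher numbers stand for an effect only at larger amounts of compound and lower numbers for an effect already at smaller amounts:

Compound 1, `COc1cccc(CNCCCNc2ccnc3cc(Oc4ccc(Cl)cc4)ccc23)c1O`, gives 5700 nM.
Compound 2, `COc1cccc(Oc2ccc3c(NCCCNCc4cc(F)ccc4OC)ccnc3c2)c1`, gives 7100 nM.
Compound 3, `COc1cccc(Oc2ccc3c(NCCCNCc4cccc(OC)c4O)ccnc3c2)c1`, gives 5300 nM.

The three numbers sit close together in this assay. Compound 2 stands at the upper edge of the group, but its gap to compound 1 is within the scatter, and the step of a 1.3-fold lower number from compound 2 to compound 3 (0.13 log units; within the scatter) is likewise within the scatter, so no ranking among the three can be drawn.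

The step from compound 2 to compound 4, `COc1ccc(F)cc1CNCCCNc1ccnc2cc(-c3ccc(F)cc3)ccc12`, replaces one aryl group on the shared core: 4-fluorophenyl in place of 3-methoxyphenoxy on an aromatic carbon. The same part of the core was varied between compound 1 and compound 3, where a 1.1-fold lower number from compound 1 to compound 3 (0.03 log units; within the scatter), and the other aryl end was varied between compound 2 and compound 3, where a 1.3-fold lower number from compound 2 to compound 3 (0.13 log units; within the scatter). Both changes left this assay essentially unmoved. Nothing measured here bears on a directly attached ring in place of an aryl ether, but on the evidence at hand no step beyond the scatter is expected.

Compound 4 is therefore estimated at 6000 nM, within a range of 2500 nM to 15000 nM, which means an expected step of a 1.2-fold lower number from compound 2 to compound 4 (0.07 log units; within the scatter).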

Compound 4, half-maximal effective concentration: 770 nM
Estimate against measurement, compound 4: 7.8-fold (0.89 log units) above; measured number below the stated range.
By their numbers in this assay, from the lowest: compound 4; then compounds 3, 1 and 2 (each within the scatter of the next).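

In this assay, this position on the shared core proves sensitive to the change: 4-fluorophenyl in place of 3-methoxyphenoxy gives a 9.2-fold lower number from compound 2 to compound 4 (0.96 log units; beyond the scatter). The earlier exchange of the ring on the ether oxygen, with a 1.1-fold lower number from compound 1 to compound 3 (0.03 log units; within the scatter), had not shown this, and so a change of aryl ether alone gave no sign of what a ring attached directly to the aromatic carbon would do. No measurement at hand accounts for the step.

The compounds shown leave open whether the step follows the loss of the ether oxygen or the exchange of the methoxy group for fluorine, which 4-fluorophenoxy at this position would help to separate. From the compounds shown here alone, it also remains open whether the 4-fluorophenyl group would have the same effect with the 2-hydroxy-3-methoxyphenyl end in place.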